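A few compounds are considered here, and "the series" means these few. Any claim that something is new, unique, unknown or untested is made for them only; others in the source may bear on it.

Going by the values given here, compound 1 `O=C(Nc1nc2ccc(F)cc2s1)c1cn(-c2ccccc2)nc1-c1ccccc1` is one of three compounds measured in a functional assay on HT-29 cells (Homo sapiens) for cytotoxicity, read by MTT assay, with a stated time of 72 h (a higher number here means a weaker inhibitor, a lower number a stronger inhibitor), where compound 1 gives 9800 nM. Compound 2 `O=C(Nc1nc2ccc(Cl)cc2s1)c1cn(-c2ccccc2)nc1-c1ccccc1` differs from it by chloro in place of fluoro on an aromatic carbon, and in this assay compound 2 gives 7810 nM, a step of a 1.3-fold lower number from compound 1 to compound 2 (0.10 log units; within the scatter). Compound 3 `O=C(Nc1nc2ccccc2s1)c1cn(-c2ccccc2)nc1-c1ccc(F)cc1` has the same atoms as compound 1, joined differently; the difference between the two cores is not broken down here. In this assay compound 3 gives 9060 nM, which sits close to the values of compound 1 and compound 2.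

Compound 4 `O=C(Nc1nc2ccccc2s1)c1cn(-c2ccccc2)nc1-c1ccc(Cl)cc1` has not been measured. It differs from compound 3 by chloro in place of fluoro on an aromatic carbon. Among the compounds with values here, this is the same kind of change as the one from compound 1 to compound 2, but the place is not the same: there the carbon lay in a ring that is part of a fused or bridged system of two rings, meta to a fused ring and para to a fused ring, whereas here it lies in a six-membered aromatic ring of carbon only, para to a large group. Because the earlier step was a 1.3-fold lower number from compound 1 to compound 2 (0.10 log units; within the scatter), compound 4 is expected to move only slightly, by a 1.2-fold lower number from compound 3 to compound 4 (0.08 log units; within the scatter). Compound 4 is therefore estimated at 7500 nM in this assay, between 3500 nM and 16000 nM.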

Compound 4, half-maximal inhibitory concentration: 13700 nM
For compound 4 the middle estimate is 1.8-fold (0.26 log units) below the measured one; the range from low to high includes it.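

In this assay, chloro in place of fluoro on the aromatic carbon, 4-fluorophenyl to 4-chlorophenyl, gives a 1.5-fold higher number from compound 3 to compound 4 (0.18 log units; within the scatter). Set beside the earlier step, this one cannot be told apart from it: the same change on two cores in this assay, a 1.3-fold lower number (0.10 log units; within the scatter) from compound 1 to compound 2 and a 1.5-fold higher number (0.18 log units; within the scatter) from compound 3 to compound 4, 1.9-fold (0.28 log units) apart, within the scatter of two such steps. Going by these compounds alone, neither step stands clear of the scatter, so the two cores give no sign that this change matters on either of them, and the opposite directions of the two steps carry no weight; this does not show that the change acts alike in both places, only that two steps this small cannot separate them.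

The compounds shown leave open whether a group other than these two halogens on that aromatic carbon, such as a methoxy group, an amine or a carboxylic acid, would give a step beyond the scatter. They also leave open whether a step of that size, if one appeared on one core, would carry over to the other.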